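A pyrrole amide replacing a fluorophenyl amide

A few compounds are considered here, and "the series" means these few. Any claim that something is new, unique, unknown or untested is made for them only; others in the source may bear on it.

Compound 1 `O=C1Nc2ccc([N+](=O)[O-])cc2/C1=C\C(=O)c1ccc(C2CCCCC2)cc1`: 2090 nM
Compound 2 `O=C1Nc2ccc(F)cc2/C1=C\C(=O)c1cnc2ccc(Cl)nn12`: 2370 nM
Compound 3 `CN1CCN(c2cccc(N/C=C3\C(=O)Nc4ccc(NC(=O)c5cccc(F)c5)cc43)c2)CC1`: 2910 nM

All three values come from a functional assay on A2780 cells (Homo sapiens) for inhibition, read by sulforhodamine B assay, with a stated time of 3 days; a lower number here means a stronger inhibitor, a higher number a weaker inhibitor. Compound 3 stands within the usual scatter of both compound 1 and compound 2, so the three values do not separate. Compound 4 `CN1CCN(c2cccc(N/C=C3\C(=O)Nc4ccc(NC(=O)c5ccc[nH]5)cc43)c2)CC1` carries 1H-pyrrol-2-yl in place of 3-fluorophenyl on a carbonyl carbon. Among the compounds with values here, no measured pair isolates this change, so the only close reference is compound 3 at 2910 nM. Only a modest step within the scatter is expected, a 1.5-fold lower number from compound 3 to compound 4 (0.16 log units; within the scatter), and its direction is uncertain. For compound 4 the estimated value is 2000 nM, with an expected range of 600 nM to 6000 nM.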

Compound 4, half-maximal inhibitory concentration: 4460 nM
The estimate for compound 4 lay 2.2-fold (0.35 log units) below the measured number; measured number inside the range.
By their numbers in this assay, from the lowest: compounds 1, 2, 3 and 4 (each within the scatter of the next, the first and the last beyond it).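

In this assay, 1H-pyrrol-2-yl in place of 3-fluorophenyl on a carbonyl carbon gives a 1.5-fold higher number from compound 3 to compound 4 (0.19 log units; within the scatter). This position therefore accepts a five-membered aromatic ring carrying a hydrogen-bond donor in place of a six-membered carbon ring, with no step beyond the scatter. No supporting measurement bears on this result. Compound 3 and compound 4 leave open whether the pyrrole hydrogen on nitrogen matters, which a pyrrole with a methyl group on that nitrogen would address. They also leave open how a pyridine ring or a saturated piperidine ring would fare here.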